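Methoxycarbonyl in place of hydroxymethyl: a clearance estimate

The source may report more compounds than this note shows. Statements on the series, on what has been measured and on what is new or still open speak of the compounds shown alone.

Measured compounds:
compound 1, `COC(=O)c1cc(N)c(Nc2ccc(C#N)cc2)cc1Oc1c(C)cc(/C=C/C#N)cc1C`: 20 mL.min-1.g-1
compound 2, `Cc1cc(CCC#N)cc(C)c1Oc1cc(Nc2ccc(C#N)cc2)c(N)cc1CO`: 330 mL.min-1.g-1

Of the compounds shown here, two have been measured in an in vitro ADME assay on microsomes from liver (Homo sapiens) for metabolic stability, tested at 1 uM; on this read-out lower numbers stand for slow clearance and higher numbers for fast clearance. Compound 2 stands highest of the two numbers; its nearest neighbour, compound 1, sits at 20 mL.min-1.g-1, a gap that lies beyond the usual scatter of this assay. Among the compounds with values here, compound 1 and compound 2 differ in more than one place, so their two values show only that the shared core tolerates a wide spread of clearance.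

The next compound, compound 3, `COC(=O)c1cc(N)c(Nc2ccc(C#N)cc2)cc1Oc1c(C)cc(CCC#N)cc1C`, has not yet been measured in this assay. It keeps the propanenitrile chain of compound 2 and changes one group: methoxycarbonyl in place of hydroxymethyl on an aromatic carbon. This brings compound 3 closer in structure to compound 1, which carries the same methoxycarbonyl group and gives 20 mL.min-1.g-1 in this assay.

Within the data shown here, with no single-change step between measured compounds available, the size of the step is uncertain. The step of a 5.5-fold lower number from compound 2 to compound 3 (0.74 log units; beyond the scatter) is expected to run downward, beyond the scatter, but short of the full gap to compound 1. Compound 3 is therefore estimated at 60 mL.min-1.g-1, with a range from 20 mL.min-1.g-1 to 180 mL.min-1.g-1.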

Compound 3, intrinsic clearance in microsomes in the Homo sapiens assay: 40 mL.min-1.g-1
Compound 3: the middle estimate sits 1.5-fold (0.18 log units) above what was measured; the measured number falls inside the stated range.
By their numbers in the Homo sapiens assay, from the lowest: compounds 1 and 3 (each within the scatter of the next); then compound 2.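

Methoxycarbonyl in place of hydroxymethyl on this aromatic carbon, para to the (4-cyanophenyl)amino group, can now be read as a single change: in the Homo sapiens assay it gives an 8.3-fold lower number from compound 2 to compound 3 (0.92 log units; beyond the scatter). The change in the side chain reads differently, since 2-cyanoethyl in place of 2-cyanoethenyl gives a 2.0-fold higher number from compound 1 to compound 3 (0.30 log units; within the scatter), so among these three compounds the large spread in clearance numbers goes with the group on this aromatic carbon and not with the chain. In a physicochemical assay for solubility, with a stated time of 4 h, at pH 2.0 (on this read-out higher numbers stand for higher solubility and lower numbers for lower solubility), compound 2 gives 89.8 ug/mL and compound 3 gives 21.8 ug/mL, which is a 4.1-fold lower number from compound 2 to compound 3 (0.61 log units; beyond the scatter), so in this one pair the lower clearance number comes with a lower solubility number.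

The compounds shown leave open whether the two read-outs must move together at this position, as only one pair carries both. A carboxylic acid, a primary amide or a longer ester on the same aromatic carbon could show whether a low clearance number can be kept alongside a solubility number nearer that of compound 2.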